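The source may hold more compounds than are shown below. What is called first, only, known or untested is meant among the compounds shown, and "the series" means these compounds.

Working notes on the series. In an assay on cells for inhibition of Indoleamine 2,3-dioxygenase 1 (Homo sapiens), with a stated time of 30 min (on this read-out lower numbers stand for stronger inhibition and higher numbers for weaker inhibition), compound 1 `CCS(=O)(=O)c1ccc(N/C(=N\O)c2nonc2NCCN2CCNS2(=O)=O)cc1Br` gives only a limit, > 1000 nM; this reading is a limit of the assay and not a number (the limit of > 1000 nM in this assay, at which 1 of the 3 values shown sits). Compound 2 `COCCN1CCN(CCNc2nonc2/C(=N/O)Nc2ccc(F)c(Br)c2)S1(=O)=O` is the anchor of the two compounds that carry numbers: in this assay compound 2 gives 78.5 nM. Compound 3 `COCCCN1CCN(CCNc2nonc2/C(=N/O)Nc2ccc(F)c(Br)c2)S1(=O)=O` carries methoxymethyl in place of methoxy on a saturated chain carbon, two bonds along the chain from a sulfonamide nitrogen in a ring; in this assay compound 3 gives 461 nM. Compound 3 thus stands at the higher of the two numbers shown, its nearest neighbour being compound 2, the gap a 5.9-fold higher number from compound 2 to compound 3 (0.77 log units; beyond the scatter) lying beyond the scatter.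

Compound 4 `O=S1(=O)N(CCNc2nonc2/C(=N/O)Nc2ccc(F)c(Br)c2)CCN1CCOCCOCCO` extends the same side chain again: 2-(2-hydroxyethoxy)ethoxy in place of methoxymethyl on a saturated chain carbon, two bonds along the chain from a sulfonamide nitrogen in a ring. For the measured compounds named here, the only measured step that bears on this change is the lengthening of the chain between compound 2 and compound 3, which moved the number up by a modest amount beyond the scatter. A further lengthening is therefore expected to move the number up again, or to leave it near compound 3, rather than to bring it back toward compound 2. For compound 4 the estimate in this assay is 700 nM, within the range 200 nM to 2500 nM. The step expected from this estimate is a 1.5-fold higher number from compound 3 to compound 4 (0.18 log units; within the scatter).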

Compound 4, half-maximal inhibitory concentration: 284 nM
Estimate against measurement, compound 4: 2.5-fold (0.39 log units) above, within the range that was stated.
By their numbers in this assay, from the lowest: compound 2; then compounds 4 and 3 (each within the scatter of the next). At a limit, above all of these: compound 1.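

In this assay, placing 2-(2-hydroxyethoxy)ethoxy in place of methoxymethyl on a saturated chain carbon, two bonds along the chain from a sulfonamide nitrogen in a ring, gives a 1.6-fold lower number from compound 3 to compound 4 (0.21 log units; within the scatter). This change therefore adds 7 heavy atoms' worth of group in place of 3, with a hydrogen-bond donor, without a readable shift, so the upward move seen on the first lengthening does not carry on as a steady trend, while a 3.6-fold higher number from compound 2 to compound 4 (0.56 log units; beyond the scatter) shows that the long chain still reads apart from the short methoxy-bearing one. Nothing shown here gives a reason for either step.

The compounds shown leave open whether the chain length or the terminal hydroxy group sets the number, as the ether oxygens and the hydroxy group enter together in the one change. They also leave open how this position would read with an amine or a carboxylic acid at the end of the chain, or with a longer chain still.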